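Working notes on the step to compound 4

A few compounds are considered here, and "the series" means these few. Any claim that something is new, unique, unknown or untested is made for them only; others in the source may bear on it.

Values in a functional assay on HepG2 cells (Homo sapiens) for inhibition, read by MTT assay, with a stated time of 72 h; on this read-out higher numbers stand for weaker inhibition and lower numbers for stronger inhibition:
- compound 1 `Cc1ccc(NC(=O)C2CCN(C/C=C/c3ccccc3)CC2)cc1`: 33900 nM
- compound 2 `CCCc1ccc(NC(=O)C2CCN(C/C=C/c3ccccc3)CC2)cc1`: 9410 nM
- compound 3 `CC(C)c1ccc(NC(=O)C2CCN(C/C=C/c3ccccc3)CC2)cc1`: 12200 nM

Compound 3 stands in the middle of the three numbers at 12200 nM. Its gap to compound 2 lies within the scatter, and compound 1 sits clearly higher. The change to compound 4 `COc1ccc(NC(=O)C2CCN(C/C=C/c3ccccc3)CC2)cc1` is methoxy in place of isopropyl on an aromatic carbon. Among the compounds with values here, two measured steps bear on it, a 2.8-fold lower number from compound 1 to compound 3 (0.44 log units; beyond the scatter) and a 3.6-fold lower number from compound 1 to compound 2 (0.56 log units; beyond the scatter), both modest, while a 1.3-fold higher number from compound 2 to compound 3 (0.11 log units; within the scatter) stays within the scatter. Within the data shown here, no methoxy compound has been measured yet, so the guidance is indirect. A modest step to a higher number is expected in this assay, with compound 1 at 33900 nM as the guide. The expected step is a 1.6-fold higher number from compound 3 to compound 4 (0.21 log units; within the scatter). For compound 4 the estimated value is 20000 nM, with an expected range of 8000 nM to 45000 nM.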

Compound 4, half-maximal inhibitory concentration: 88800 nM
Beside the measured number, compound 4's estimate is 4.4-fold (0.65 log units) below it; the whole stated range lies below it.
By their numbers in this assay, from the lowest: compounds 2 and 3 (each within the scatter of the next); then compound 1; then compound 4.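

In this assay methoxy at this aromatic carbon gives a 7.3-fold higher number from compound 3 to compound 4 (0.86 log units; beyond the scatter) and a 9.4-fold higher number from compound 2 to compound 4 (0.97 log units; beyond the scatter), both larger than any step among the alkyl compounds. Methoxy also ends above methyl, with a 2.6-fold higher number from compound 1 to compound 4 (0.42 log units; beyond the scatter), so the lower numbers seen with propyl and isopropyl do not carry over to this group. Of the groups compared here, methoxy alone carries a hydrogen-bond acceptor, though that count alone explains nothing.

From the compounds shown here alone, whether ethoxy, a hydroxyl or an amine at this carbon would track methoxy or the alkyl groups remains open. No available data account for these steps.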